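The source may hold more compounds than are shown below. What is called first, only, known or untested is meant among the compounds shown, and "the series" means these compounds.

Compound 1, `C#CCSc1nc(Nc2ccccc2Cl)c2ccncc2n1`: > 80000 nM
Compound 2, `C#CCSc1nc(Nc2ccc(Cl)cc2)c2ccncc2n1`: 19000 nM

In a functional assay on PC-3 cells (Homo sapiens) for inhibition, read by MTT assay, with a stated time of 72 h (a lower number here means a stronger inhibitor, a higher number a weaker inhibitor), compound 1 gives only a limit, > 80000 nM. Compound 2 gives 19000 nM in this assay, and this is the only number shown. The value of compound 1 is a limit of this assay, (the limit of > 80000 nM in this assay, at which 1 of the 2 values shown sits). Among the compounds with values here, the one measured step, an at least 4.2-fold lower number from compound 1 to compound 2 (0.62 log units; beyond the scatter), reads as a shift from a limit to a number, so its true size is not known beyond its lower bound.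

Compound 3 is `C#CCSc1nc(Nc2ccc(O)cc2)c2ccncc2n1`. The change from compound 2 is hydroxy in place of chloro on an aromatic carbon. Within the data shown here, no measured step concerns this exchange: the step from compound 1 to compound 2 alters where the chloro sits, not what stands in its place, so it gives no direct guide. With the measured values the expectation can only be anchored on compound 2, and the step is expected to be small, a 1.6-fold higher number from compound 2 to compound 3 (0.20 log units; within the scatter), with a wide uncertainty that reaches the limit of this assay. Compound 3 is estimated at 30000 nM in this assay, within a range from 8000 nM to 100000 nM.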

Compound 3, half-maximal inhibitory concentration: > 80000 nM
Compound 3: a limit, no number (the forecaster's own chance of this, stated with the estimate: 30%); middle value at least 2.6-fold (0.42 log units) away from the limit.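

The exchange of 4-chlorophenyl for 4-hydroxyphenyl is the first change shown that replaces the group itself rather than moving it, and in this assay it gives an at least 4.2-fold higher number from compound 2 to compound 3 (0.62 log units; beyond the scatter). With the place of the substituent held as in compound 2, hydroxy in place of chloro is enough to lose the measurable number, so that number does not depend on the position of the substituent alone, and compound 2 remains the only one of the three with a value that is not a limit. The step from compound 1 to compound 3 cannot be read, because both compounds sit at a limit: the limit of > 80000 nM in this assay, at which 2 of the 3 values shown sit.

The compounds shown leave open how far compound 3 truly stands from compound 2, as only the lower bound of that step is known. They also leave open whether the number of compound 2 is particular to chloro, or whether a methoxy group, an amine or a fluoro group in the same place would give a number as well.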